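Trimethoxyphenyl ketone variant of a nucleoside ester conjugate

A few compounds are considered here, and "the series" means these few. Any claim that something is new, unique, unknown or untested is made for them only; others in the source may bear on it.

The measured compounds are compound 1 `COc1cccc(C(=O)c2ccc(OC)c(OC(=O)CCC(=O)OC[C@@H]3C=C[C@H](n4cc(C)c(=O)[nH]c4=O)O3)c2)c1`, compound 2 `COc1ccc(C(=O)c2ccc(F)cc2)cc1OCC(=O)OC[C@@H]1C=C[C@H](n2cc(C)c(=O)[nH]c2=O)O1` and compound 3 `COc1ccc(C(=O)c2ccccc2OC)cc1OCC(=O)OC[C@@H]1C=C[C@H](n2cc(C)c(=O)[nH]c2=O)O1`. In a functional assay on SMMC-7721 cells (Homo sapiens) for antiproliferative activity, read by MTT assay, with a stated time of 48 h (a lower number here means a stronger inhibitor, a higher number a weaker inhibitor), compound 1 gives 820 nM, compound 2 gives 40300 nM and compound 3 gives 32300 nM.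

Compound 1 holds the lowest of the three numbers, beyond the scatter from both others. Compound 4 `COc1cc(OC)c(C(=O)c2ccc(OC)c(OC(=O)CCC(=O)OC[C@@H]3C=C[C@H](n4cc(C)c(=O)[nH]c4=O)O3)c2)cc1OC` differs from it by 2,4,5-trimethoxyphenyl in place of 3-methoxyphenyl on a carbonyl carbon. For the measured compounds named here, the only step that bears on an aryl exchange at this carbonyl carbon is a 1.2-fold lower number from compound 2 to compound 3 (0.10 log units; within the scatter), which was within the scatter. That step, though taken on a different ester linker, suggests the aryl exchange itself shifts the number little. Compound 4 is therefore expected near compound 1, an estimated 700 nM with a range of 200 nM to 2500 nM, meaning an expected 1.2-fold lower number from compound 1 to compound 4 (0.07 log units; within the scatter).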

Compound 4, half-maximal inhibitory concentration: 2860 nM
Beside the measured number, compound 4's estimate is 4.1-fold (0.61 log units) below it, and the stated range ends below it.
By their numbers in this assay, from the lowest: compound 1; then compound 4; then compounds 3 and 2 (each within the scatter of the next).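

With the linker of compound 1 held fixed in this assay, placing 2,4,5-trimethoxyphenyl in place of 3-methoxyphenyl on a carbonyl carbon gives a 3.5-fold higher number from compound 1 to compound 4 (0.54 log units; beyond the scatter) and so lies beyond the scatter. The earlier aryl exchange, on a different linker, gave a 1.2-fold lower number from compound 2 to compound 3 (0.10 log units; within the scatter) and stayed within it, so this position is now seen to respond to the aryl group. Nothing available accounts for this rise.

Which of the added methoxy groups carries the rise remains open. Also open, going by these compounds, is how an aryl group bearing an amine or a carboxylic acid would read at this carbonyl carbon.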